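The source may hold more compounds than are shown below. What is called first, only, known or untested is meant among the compounds shown, and "the series" means these compounds.

Series notes. The shared core of compound 1, `CCOC(=O)CN(C)C(=O)c1ccc(C(CC)(CC)c2ccc(OCC(=O)C(C)(C)C)c(C)c2)n1CC`, carries an amide on one side and a tert-butyl ketone on the other; in an assay on HL-60 cells for agonist activity at vitamin D3 receptor (Homo sapiens), read by microscopy, with a stated time of 96 h (a higher number here means that more compound is needed for the effect, a lower number that less compound is needed), compound 1 gives only a limit, > 50000 nM. Compound 2, `C#CCNC(=O)c1ccc(C(CC)(CC)c2ccc(OCC(=O)C(C)(C)C)c(C)c2)n1CC`, gives 2200 nM in this assay, and the step of an at least 22-fold lower number from compound 1 to compound 2 (1.35 log units; beyond the scatter) shows that the amide substituent can move the number a long way. Compound 3, `CCOC(=O)CN(C)C(=O)c1ccc(C(CC)(CC)c2ccc(OCC(O)C(C)(C)C)c(C)c2)n1CC`, gives 210 nM in this assay; the step of an at least 230-fold lower number from compound 1 to compound 3 (2.37 log units; beyond the scatter) is the largest seen, set against compound 1 sitting at the limit of > 50000 nM in this assay, at which 1 of the 3 values shown sits. Among the numbers shown compound 3 stands lowest, with compound 2 the nearest at a higher value beyond the scatter.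

Compound 4, `CCn1c(C(=O)N(C)CCC#N)ccc1C(CC)(CC)c1ccc(OCC(O)C(C)(C)C)c(C)c1`, is the next step from compound 3: cyanomethyl in place of ethoxycarbonyl on a saturated chain carbon bound to an amide-type nitrogen. Of the measured steps only the change from compound 1 to compound 2 touches the amide substituent, and it lowered the number substantially when the ester-bearing group was exchanged; the change from compound 1 to compound 3 does not bear on the amide. A change at this position in this assay is therefore expected to matter, most likely toward a somewhat lower number, though the direction rests on a single step. Compound 4 is expected in this assay at 130 nM, with a range from 35 nM to 500 nM. The expected step is a 1.6-fold lower number from compound 3 to compound 4 (0.21 log units; within the scatter).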

Compound 4, half-maximal effective concentration: 1960 nM
The estimate for compound 4 lay 15-fold (1.18 log units) below the measured number; measured number above the stated range.
By their numbers in this assay, from the lowest: compound 3; then compounds 4 and 2 (each within the scatter of the next). At a limit, above all of these: compound 1.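

In this assay, the amide substituent also moves the number when the hydroxy group of compound 3 is held constant: a 9.3-fold higher number from compound 3 to compound 4 (0.97 log units; beyond the scatter), so ethoxycarbonyl is not interchangeable with cyanomethyl at this place, on a saturated chain carbon bound to an amide-type nitrogen. The earlier step at the amide, an at least 22-fold lower number from compound 1 to compound 2 (1.35 log units; beyond the scatter), went the opposite way on removal of the ester-bearing group, so that removal has no fixed direction across the two pairs, although the entering groups and the rest of the structures differ, and the earlier step is read against a limit. Nothing measured here explains why the number rises with this exchange.

Still open, going by these compounds, is whether 2-cyanoethyl would have the same effect on the tert-butyl ketone side, and whether propargylamino on the hydroxy side would keep the lowering seen in the ketone pair, which would separate the effect of the substituent from that of its background. Also open, on these data alone, is whether a carboxylic acid in place of ethoxycarbonyl, or a longer chain carrying the ester, would hold the number near that of compound 3, 210 nM.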